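Turning the stereocentre of compound 1

This account rests on a few compounds, and the source may have more. Where it says the series, first, only, none or still open, it means among the compounds named here.

Compound 1, `C[C@@H](C(=O)O)c1nn(Cc2cn3cc(OCC4CC4)c(Cl)cc3n2)c2ccccc2c1=O`: 24 nM
Compound 2, `COc1ccc(NC(=O)Cc2nn(CC(=O)O)c(=O)c3ccccc23)c(OC)c1`: > 19900 nM
Compound 3, `C[C@H](C(=O)O)c1nn(Cc2cn3cc(OCC4CC4)c(Cl)cc3n2)c2ccccc2c1=O`: not yet measured

Of the compounds shown here, two have been tested in a functional assay on CHO cells for antagonist activity at sphingosine 1-phosphate receptor 2 (Homo sapiens), read by calcium flux; a higher number here means a weaker inhibitor, a lower number a stronger inhibitor. Compound 1 `C[C@@H](C(=O)O)c1nn(Cc2cn3cc(OCC4CC4)c(Cl)cc3n2)c2ccccc2c1=O` gives 24 nM. Compound 2 `COc1ccc(NC(=O)Cc2nn(CC(=O)O)c(=O)c3ccccc23)c(OC)c1` is reported only as a limit of the assay, > 19900 nM, so no number is known for it. Among the compounds with values here, compound 1 therefore holds the only actual number in this assay; the other entry sits at the limit of > 19900 nM in this assay, at which 1 of the 2 values shown sits. No step between two measured compounds is shown, as the two differ in many places at once.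

Compound 3 `C[C@H](C(=O)O)c1nn(Cc2cn3cc(OCC4CC4)c(Cl)cc3n2)c2ccccc2c1=O` is the untested partner of compound 1. The difference is the two compounds have the same atoms and bonds and differ only in configuration as drawn: 1 of 1 stereo elements differ; a stereocentre at a saturated chain carbon is drawn R in compound 1 and S in compound 3. Nothing measured here tells how this assay responds to that inversion, so the size of the step is open. Compound 1 at 24 nM is a strong inhibitor, and the other configuration is expected, with wide uncertainty, to be weaker, so the step from a 10-fold higher number from compound 1 to compound 3 (1.02 log units; beyond the scatter) is estimated to go toward weaker inhibition. For compound 3 the estimate in this assay is 250 nM, within 25 nM to 3000 nM.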

Compound 3, half-maximal inhibitory concentration: 3.2 nM
Compound 3: middle estimate off by 78-fold (1.89 log units), on the high side; the measured number lies below the stated range.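

In this assay, inverting the stereocentre at a saturated chain carbon from R to S gives a 7.5-fold lower number from compound 1 to compound 3 (0.88 log units; beyond the scatter), so this centre is a position where the drawn configuration alone changes the reading, and the S form is the stronger inhibitor of this pair. Within the data shown here, the earlier compounds offered no step at all, and this pair gives the first reading of any single change, one that can be assigned to configuration alone because nothing else differs: the fact that compounds 1 and 3 differ only in the configuration as drawn. Compound 2 remains a limit of the assay at > 19900 nM and differs from both of these compounds in many places, so it adds nothing to the reading of this centre.

The compounds shown do not tell why the S configuration gives the lower number, or whether the same order would hold with an ethyl group or a hydroxyl group in place of the methyl group at that carbon. Among these compounds, they also leave open whether the step depends on the carboxylic acid, since no compound here carries an amide or an ester at that place on the chain.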